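The source may report more compounds than this note shows. Statements on the series, on what has been measured and on what is new or still open speak of the compounds shown alone.

Of the compounds shown here, three of one shared core have been tested in a functional assay on A549 cells (Homo sapiens) for inhibition, read by MTT assay, with a stated time of 72 h; a lower number here means a stronger inhibitor, a higher number a weaker inhibitor. Compound 1 `O=C(NNC(=O)C1CC1c1ccc(OC(F)(F)F)cc1)c1ccncc1` gives 56000 nM in this assay. Compound 2 `COc1ccc(C2CC2C(=O)NNc2nncc3ccccc23)cc1` gives 96000 nM in this assay, and compound 3 `O=C(NNc1nncc2ccccc12)C1CC1c1ccc(OCC(F)(F)F)cc1` gives 48000 nM. Among these three numbers compound 1 stands second highest; its nearest neighbour is compound 3, its furthest compound 2, and both of those gaps lie within the scatter, so the three compounds cannot be told apart on these numbers.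

For the measured compounds named here, the one change examined in a single place is the step of a 2.0-fold lower number from compound 2 to compound 3 (0.30 log units; within the scatter), which is within the scatter.

The next compound to be tested is compound 4 `CC(C)=CCC/C(C)=C/COc1ccc(C2CC2C(=O)NNC(=O)c2ccncc2)cc1`. It differs from compound 1 in one place: 3,7-dimethylocta-2,6-dien-1-yl in place of trifluoromethyl on an oxygen on an aromatic ring. Going by the values given here, no measured step covers this change. Among the compounds with values here, the only step at the same oxygen, the step from compound 2 to compound 3, stayed within the scatter, and no other compound carries a chain of this kind on that oxygen. With nothing pointing in either direction, the expectation for this assay is no step beyond the scatter, and the estimated step of a 1.1-fold lower number from compound 1 to compound 4 (0.05 log units; within the scatter) carries a wide uncertainty. Compound 4 is therefore estimated to give 50000 nM in this assay, with a range from 15000 nM to 160000 nM.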

Compound 4, half-maximal inhibitory concentration: 78000 nM
The estimate for compound 4 lay 1.6-fold (0.19 log units) below the measured number, and the stated range covers the measured number.
By their numbers in this assay, from the lowest: compounds 3, 1, 4 and 2 (each within the scatter of the next).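

In this assay, putting 3,7-dimethylocta-2,6-dien-1-yl in place of trifluoromethyl on the oxygen gives a 1.4-fold higher number from compound 1 to compound 4 (0.14 log units; within the scatter). The earlier step at this oxygen, a 2.0-fold lower number from compound 2 to compound 3 (0.30 log units; within the scatter), involved only a trifluoromethyl in place of a hydrogen on a saturated chain carbon, whereas here a chain of 10 heavy atoms with 2 double bonds replaces a group of 4 heavy atoms, and the number still does not move beyond the scatter, so on this pair a large difference in the size of the group on this oxygen brings no readable change. The data shown offer no measurement that bears on why this is so.

The compounds shown leave open whether any group on this oxygen can move the number beyond the scatter, for example an amine or a carboxylic acid at the end of a chain, or a plain hydrogen giving a free hydroxyl. They also leave open whether 3,7-dimethylocta-2,6-dien-1-yl would behave the same way on the core of compound 2, which differs from compound 1 in more than this one place.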